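Swapping Chloro for Methoxy: Cytotoxicity Expectations

The source may hold more compounds than are shown below. What is called first, only, known or untested is meant among the compounds shown, and "the series" means these compounds.

Two compounds were examined in an ADME assay on HEL cells (Homo sapiens) for cytotoxicity, read by microscopy; on this read-out lower numbers stand for higher toxicity in this test and higher numbers for lower toxicity in this test. Compound 1 `Nc1nc(O)c2ncn(CSC(CO)CO)c2n1` reaches only the limit of this assay, reported as > 50000 nM, which is a limit rather than a number. Compound 2 `Nc1nc(Cl)c2ncn(CCC(CO)CO)c2n1` likewise gives a limit in this assay, namely > 50000 nM. Among the compounds with values here, compound 2 therefore stands at the edge of what this assay can report, and both values shown sit at the limit of > 50000 nM in this assay, at which 2 of the 2 values shown sit, so no step between measured compounds can be stated, and the two limits allow no ordering of compound 1 and compound 2.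

Compound 3 `COc1nc(N)nc2c1ncn2CCC(CO)CO` differs from compound 2 by methoxy in place of chloro on an aromatic carbon. With both measured compounds resting at the same limit, the data give no indication of a change in cytotoxicity, and the step expected in this assay is none beyond the scatter. The estimated step from compound 2 to compound 3 is a number no higher from compound 2 to compound 3 (the limit leaves the size open), expected to lie within scatter. Compound 3 is accordingly expected to show 50000 nM, within a range from 25000 nM to 100000 nM, most likely reported once more only as a limit.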

Compound 3, minimum cytotoxic concentration: > 50000 nM
Compound 3 was reported as a limit (the forecaster's own chance of this, stated with the estimate: 85%); the middle value lies on the limit itself.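

In this assay compound 3 gives > 50000 nM, which is a limit and not a number. No step from compound 2 to compound 3 can be read, as all three compounds rest at the same limit: the limit of > 50000 nM in this assay, at which 3 of the 3 values shown sit.

The compounds shown leave open whether methoxy in place of chloro on an aromatic carbon alters cytotoxicity at all.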